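Trimming a Furan Side Chain on a Shared Core

The compounds below may be only part of what the source reports. "The series", "measured", "known", "first", "only" and "open" are said of these compounds alone.

Measured compounds:
Compound 1, `COc1ccc(CNc2nc(NCc3ccccc3)nc3ccccc23)cc1`, gives 5200 nM in an ADME assay on J774.A1 cells (Mus musculus) for inhibition, read by MTT assay, with a stated time of 72 h; a higher number here means that more compound is needed for the effect, a lower number that less compound is needed.
Compound 2, `CNc1nc(NCc2ccco2)nc2ccccc12`, is recorded as "not determined" (no result reported) in this assay.

For the measured compounds named here, compound 2 therefore has no number to stand on; the only measured value in this set belongs to compound 1, which gives 5200 nM. Compound 3, `CNc1nc(NC)c2ccccc2n1`, differs from compound 2 in a single place: hydrogen in place of furan-2-yl on a saturated chain carbon bound to a nitrogen on an aromatic ring. Going by the values given here, no pair of measured compounds here differs in one place, so no measured step exists to set the scale of this change. The expectation is that compound 3 needs more compound than compound 2 would, a step in the upward direction that may well exceed the usual scatter, though with only the value of compound 1 as a distant anchor the uncertainty is wide. Compound 3 is estimated at 15000 nM, within a range from 4000 nM to 60000 nM.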

Compound 3, half-maximal effective concentration: > 133000 nM
Compound 3 gave a limit, no number (the forecaster's own chance of this, stated with the estimate: 40%); middle value at least 8.8-fold (0.94 log units) from the limit.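

No step from compound 2 to compound 3 can be read, since compound 2 has no number to compare and compound 3 gives only a limit: the limit of > 133000 nM in this assay, at which 1 of the 3 values shown sits.

The compounds shown leave open how far the change from (furan-2-yl)methyl to methyl shifts the result in this assay.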